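Selenium-bearing group for methylsulfanyl: compound 4 expected

This account rests on a few compounds, and the source may have more. Where it says the series, first, only, none or still open, it means among the compounds named here.

Three compounds have been measured in a functional assay on HT-29 cells (Homo sapiens) for cytotoxicity, read by MTT assay, with a stated time of 72 h; a lower number here means a stronger inhibitor of growth, a higher number a weaker inhibitor of growth:

Compound 1 `CS/C(=N\C(=O)c1csc([N+](=O)[O-])c1)NC(=O)c1csc([N+](=O)[O-])c1` gives > 100000 nM
Compound 2 `O=C(/N=C(/NC(=O)c1cccs1)[Se]Cc1ccccc1)c1cccs1` gives > 100000 nM
Compound 3 `CS/C(=N\C(=O)c1cccs1)NC(=O)c1cccs1` gives > 100000 nM

Each of these values is a limit of the assay, not a number. Compound 2 differs from compound 3 by a group of 8 heavy atoms (7 carbon, 1 selenium; one six-membered aromatic ring of carbon only) in place of a group of 2 heavy atoms (1 carbon, 1 sulfur; no ring), on a carbon with a double bond to nitrogen. The step that the two limits leave unreadable from compound 3 to compound 2 cannot be sized, because both ends rest on (the limit of > 100000 nM in this assay, at which 3 of the 3 values shown sit). Compound 4 `O=C(/N=C(/NC(=O)c1csc([N+](=O)[O-])c1)[Se]Cc1ccccc1)c1csc([N+](=O)[O-])c1` carries the same change relative to compound 1, namely (a group of 8 heavy atoms (7 carbon, 1 selenium; one six-membered aromatic ring of carbon only) in place of a group of 2 heavy atoms (1 carbon, 1 sulfur; no ring), on a carbon with a double bond to nitrogen). The difference between the cores of compound 1 and compound 3 is not broken down here; compound 1 carries the nitro-bearing version, and both cores behave alike so far.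

With no readable step to lean on, the expectation for compound 4 rests only on the same change having left compound 2 at the limit, shown by the limit of > 100000 nM in this assay, at which 3 of the 3 values shown sit. The step from compound 1 is therefore expected to be a number no higher from compound 1 to compound 4 (the limit leaves the size open). Compound 4 is estimated at 100000 nM, most likely reported again only as a limit, between 30000 nM and 300000 nM.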

Compound 4, concentration for total growth inhibition: > 100000 nM
Compound 4 gave a limit, no number; the forecaster's own chance of this, stated with the estimate: 85%; the middle value lies on the limit itself.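

Compound 4, like compound 1, is reported only as a limit of the assay and not as a number, so no size can be read for the step between them: the limit of > 100000 nM in this assay, at which 4 of the 4 values shown sit.

The compounds shown leave open whether swapping methylsulfanyl for the selenium-bearing group, or using the nitro-bearing core, changes growth inhibition in this assay at all.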